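Replacing the Chloro Group of Compound 3

The source may report more compounds than this note shows. Statements on the series, on what has been measured and on what is new or still open speak of the compounds shown alone.

Of the compounds shown here, three sharing one core have been measured in an ADME assay on microsomes from liver (Rattus norvegicus) for metabolic stability; a lower number here means slower removal, a higher number faster removal of the compound. Compound 1 `CNc1nc(NC2(C#N)CCCCC2)nc(-n2cccn2)n1` gives 103 mL/min/kg, compound 2 `CNc1nc(NC)nc(NC2(C#N)CCCCC2)n1` gives 210 mL/min/kg, and compound 3 `CNc1nc(Cl)nc(NC2(C#N)CCCCC2)n1` gives 867 mL/min/kg, the highest number of the three.

Compound 4 `CNc1nc(NC2(C#N)CCCCC2)nc(-n2cnc(C#N)n2)n1` differs from compound 3 in one place, on an aromatic carbon between two ring nitrogen atoms: 3-cyano-1H-1,2,4-triazol-1-yl in place of chloro on an aromatic carbon. The chloro group leaves, and a 3-cyano-1H-1,2,4-triazol-1-yl group enters.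

Two measured steps involve the same chloro group. The closer guide is an 8.4-fold higher number from compound 1 to compound 3 (0.93 log units; beyond the scatter), since compound 1 also carries a five-membered aromatic ring at this carbon, as its 1H-pyrazol-1-yl group. The other is a 4.1-fold higher number from compound 2 to compound 3 (0.62 log units; beyond the scatter), where methylamino gives way to chloro. Both steps rise on arriving at chloro, so in these two comparisons the chloro compound has the higher number. The step between the two non-chloro compounds is smaller: a 2.0-fold higher number from compound 1 to compound 2 (0.31 log units; beyond the scatter).

A clear fall in this assay is therefore expected on leaving chloro, similar in size to the step from the pyrazolyl compound. The expected step is a 6.7-fold lower number from compound 3 to compound 4 (0.82 log units; beyond the scatter). Going by the values given here, no measured compound carries the new group, so the range stays wide. For compound 4 the estimated clearance is 130 mL/min/kg, with an expected range from 50 mL/min/kg to 340 mL/min/kg.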

Compound 4, clearance: 210 mL/min/kg
For compound 4 the middle estimate is 1.6-fold (0.21 log units) below the measured one; the range from low to high includes it.
By their numbers in this assay, from the lowest: compound 1; then compounds 2 and 4 (each within the scatter of the next); then compound 3.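

In this assay, going by these compounds alone, the new group confirms that chloro is not needed at this carbon: the change gives a 4.1-fold lower number from compound 3 to compound 4 (0.62 log units; beyond the scatter) and so makes chloro the highest against a third replacement, with no compound here going against that pattern. The new group also does not match the pyrazolyl group, since the two five-membered aromatic rings are separated by a 2.0-fold higher number from compound 1 to compound 4 (0.31 log units; beyond the scatter) and the kind of ring at this carbon therefore matters to the number. At the same time, a group as large as 3-cyano-1H-1,2,4-triazol-1-yl ends up level with the small methylamino group, with no change at the digits printed from compound 2 to compound 4 (within the scatter) in this assay, and no evidence is available to explain any of these differences.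

The compounds shown cannot say whether the extra ring nitrogen atoms or the nitrile separates compound 4 from compound 1, a question that an unsubstituted 1H-1,2,4-triazol-1-yl group at the same carbon would address. Going by these compounds, whether any group, such as morpholine or a simple methoxy, could bring the number under that of compound 1 also remains open.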